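The compounds below may be only part of what the source reports. "The series", "measured", "known", "first", "only" and "open" are said of these compounds alone.

Four related compounds are compared in a functional assay on MCF7 cells (Homo sapiens) for cytotoxicity, read by MTT assay, with a stated time of 72 h; on this read-out higher numbers stand for weaker inhibition of growth and lower numbers for stronger inhibition of growth. Compound 1 `CS/C(=N\C(=O)c1ccno1)NC(=O)c1ccno1` gives 77800 nM, and compound 2 `O=C(/N=C(/NC(=O)c1ccno1)[Se]Cc1ccccc1)c1ccno1` gives 7800 nM. These two differ in one place: a group of 2 heavy atoms (1 carbon, 1 sulfur; no ring) in place of a group of 8 heavy atoms (7 carbon, 1 selenium; one six-membered aromatic ring of carbon only), on a carbon with a double bond to nitrogen, and that change made a 10-fold higher number from compound 2 to compound 1 (1.00 log units; beyond the scatter). Compound 3 `O=C(/N=C(/NC(=O)c1cccs1)[Se]Cc1ccccc1)c1cccs1` carries the same group as compound 2 on that carbon but on a different core; how the two cores differ is not broken down here. In this assay compound 3 gives 72500 nM. Compound 4 `CS/C(=N\C(=O)c1cccs1)NC(=O)c1cccs1` arises from compound 3 by the same change: a group of 2 heavy atoms (1 carbon, 1 sulfur; no ring) in place of a group of 8 heavy atoms (7 carbon, 1 selenium; one six-membered aromatic ring of carbon only), on a carbon with a double bond to nitrogen. A step in the same direction, though possibly smaller, is expected, a 3.4-fold higher number from compound 3 to compound 4 (0.54 log units; beyond the scatter), because compound 3 gives 72500 nM, a number near where such a measurement may stop giving a value. Compound 4 is therefore estimated at 250000 nM, expected to lie between 70000 nM and 900000 nM.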

Compound 4, concentration for 50% growth inhibition: 44500 nM
For compound 4 the middle estimate is 5.6-fold (0.75 log units) above the measured one, and the stated range ends above it.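

Putting methylsulfanyl in place of the larger selenium-containing group gives a 1.6-fold lower number from compound 3 to compound 4 (0.21 log units; within the scatter) in this assay and so has no readable effect on this core. The same change therefore does not carry over from one core to the other with the same size: the same change on two cores in this assay, a 10-fold higher number (1.00 log units; beyond the scatter) from compound 2 to compound 1 and a 1.6-fold lower number (0.21 log units; within the scatter) from compound 3 to compound 4, 16-fold (1.21 log units) apart, beyond the scatter of two such steps. This shows that a step seen on one core cannot simply be assumed on the other, but it does not show why the two cores differ, and two pairs set no rule for the series.

The compounds shown cover only two cores and two groups on that carbon. As far as these compounds go, how an amine or a longer chain such as ethylsulfanyl would behave there on each core remains open.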